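Trifluoromethyl to Ethynyl: An Estimate for Compound 4

This account rests on a few compounds, and the source may have more. Where it says the series, first, only, none or still open, it means among the compounds named here.

Measured so far:
compound 1 `C#Cc1cccc(Nc2ncnc3ccc(NC(=O)Nc4ccc(CN5CCN(C)CC5)cc4)cc23)c1`: 5170 nM
compound 2 `CCN(CC)Cc1ccc(NC(=O)Nc2ccc3ncnc(Nc4cccc(C(F)(F)F)c4)c3c2)cc1`: 2070 nM
compound 3 `CN(C)Cc1ccc(NC(=O)Nc2ccc3ncnc(Nc4cccc(C(F)(F)F)c4)c3c2)cc1`: 1120 nM

All three were tested in a functional assay on A549 cells (Homo sapiens) for antiproliferative activity, read by MTT assay, with a stated time of 72 h; on this read-out higher numbers stand for weaker inhibition and lower numbers for stronger inhibition. Compound 2 sits second highest of the three numbers. Its nearest neighbour is compound 3, and the step of a 1.8-fold lower number from compound 2 to compound 3 (0.27 log units; within the scatter) is a change in the amine arm only. Compound 1 gives a higher number than compound 2, a gap beyond the scatter, but compound 1 differs from compound 2 in two places at once, so that gap cannot be tied to one change.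

The unmeasured compound 4 `C#Cc1cccc(Nc2ncnc3ccc(NC(=O)Nc4ccc(CN(CC)CC)cc4)cc23)c1` keeps the diethylamino arm of compound 2 and alters the other end: ethynyl in place of trifluoromethyl on an aromatic carbon. Within the data shown here, no measured step isolates this swap. Among the measured compounds shown here, the only single-change step known, from compound 2 to compound 3, concerns the amine arm and says nothing about it. The one hint is that compound 1, which carries ethynyl, gives the highest number shown, though with a different amine arm.

On that thin basis, compound 4 is expected to land somewhat above compound 2, as the step of a 1.7-fold higher number from compound 2 to compound 4 (0.23 log units; within the scatter), with wide uncertainty. The estimate for compound 4 is 3500 nM, within 1400 nM to 9000 nM.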

Compound 4, half-maximal inhibitory concentration: 2250 nM
For compound 4 the middle estimate is 1.6-fold (0.19 log units) above the measured one; measured number inside the range.
By their numbers in this assay, from the lowest: compounds 3, 2 and 4 (each within the scatter of the next); then compound 1.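

In this assay, the change from 3-(trifluoromethyl)phenyl to 3-ethynylphenyl gives a 1.1-fold higher number from compound 2 to compound 4 (0.04 log units; within the scatter), so with the diethylamino arm in place, this position takes ethynyl, with 2 heavy atoms, in place of trifluoromethyl, with 4, without a readable shift in the number. Among these compounds, the amine arm now has a measured step of its own with ethynyl held constant: diethylamino in place of 4-methylpiperazin-1-yl gives a 2.3-fold lower number from compound 1 to compound 4 (0.36 log units; beyond the scatter), a modest change but one beyond the scatter, which the earlier compounds could not separate from the change at the other end of the molecule. Nothing measured here explains why either step has the size it does.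

The compounds shown leave open whether a nitrile or a single chlorine atom in this same place would also give a number within the scatter of compound 2. They also leave open how a morpholin-4-yl or pyrrolidin-1-yl arm would compare with diethylamino, and whether the step between the 4-methylpiperazin-1-yl and diethylamino arms would keep its size with trifluoromethyl on the other end.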